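From 4-methoxyphenyl to 2-methoxyphenyl on a shared core

This account rests on a few compounds, and the source may have more. Where it says the series, first, only, none or still open, it means among the compounds named here.

In a functional assay on HepG2 cells (Homo sapiens) for antiproliferative activity (a higher number here means a weaker inhibitor, a lower number a stronger inhibitor), compound 1 `C/C1=C\CC(C)(C)/C=C/C(=O)N(Cc2cn(CCOc3ccc(C(=O)/C=C/c4ccc(C)cc4)c(O)c3)nn2)/C(C)=C/CC1` gives 0.87 ug/mL. In this assay, compound 2 `COc1ccc(/C=C/C(=O)c2ccc(OCCCN3C(=O)/C=C/C(C)(C)C/C=C(\C)CC/C=C/3C)cc2)cc1` gives 1.73 ug/mL. These two numbers lie within the usual scatter of each other, so compound 2 stands level with compound 1 on the evidence available. Compound 3 `COc1ccccc1/C=C/C(=O)c1ccc(OCCCN2C(=O)/C=C/C(C)(C)C/C=C(\C)CC/C=C/2C)cc1` has not yet been measured. It differs from compound 2 in one place: 2-methoxyphenyl in place of 4-methoxyphenyl on a double-bonded chain carbon bound to a double-bonded chain carbon, with 2-methoxyphenyl in place of 4-methoxyphenyl on a double-bonded chain carbon bound to a double-bonded chain carbon. Among the measured compounds shown here, no measured pair shows a change of this kind, so the data offer no direct guide to it. No step beyond the scatter is therefore expected in this assay, and the estimate stays close to compound 2 at 1.73 ug/mL. The expected step is a 1.1-fold higher number from compound 2 to compound 3 (0.04 log units; within the scatter). The estimated value for compound 3 is 1.9 ug/mL, within an expected range of 0.8 ug/mL to 4.5 ug/mL.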

Compound 3, half-maximal inhibitory concentration: 1.44 ug/mL
Compound 3: middle estimate off by 1.3-fold (0.12 log units), on the high side; the range from low to high includes it.
By their numbers in this assay, from the lowest: compounds 1, 3 and 2 (each within the scatter of the next).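

In this assay, setting 2-methoxyphenyl in place of 4-methoxyphenyl on a double-bonded chain carbon bound to a double-bonded chain carbon gives a 1.2-fold lower number from compound 2 to compound 3 (0.08 log units; within the scatter). Among the compounds shown here, this is the first reading of any change at this place, and on this evidence the two methoxyphenyl groups cannot be told apart on the shared core. No supporting measurement bears on this result.

The compounds shown leave open whether an amine or a carboxylic acid in place of the methoxy group on this phenyl ring would also stand level with compound 2 in this assay. As far as these compounds go, it also remains open whether 2-methoxyphenyl would read the same way on the core of compound 1, or with a longer chain in place of the methoxy group.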